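Sulfonyl aryl swap back toward chlorophenyl on the quinoline series

The compounds below may be only part of what the source reports. "The series", "measured", "known", "first", "only" and "open" are said of these compounds alone.

Three compounds of the shared core are measured in an assay on isolated protein for displacement of a labelled ligand from metabotropic glutamate receptor 5 (Homo sapiens), with a stated time of 60 min, tested at 1 uM; on this read-out higher numbers stand for more inhibition at the one concentration tested (going by the name of the read-out) and lower numbers for less inhibition. Compound 1 `COc1ccc2ncc(S(=O)(=O)c3ccc(Cl)cc3)c(N3CCC(C)CC3)c2c1` gives 91%. Compound 2 `Cc1ccc2ncc(S(=O)(=O)c3cc(Cl)cc(Cl)c3)c(N3CCC(C)CC3)c2c1`, which carries a 3,5-dichlorophenyl on the sulfonyl sulfur, gives 75%. Compound 3 `COc1cccc(S(=O)(=O)c2cnc3ccc(OC)cc3c2N2CCC(C)CC2)c1` gives 0% and stands lowest of the three, with compound 2 nearest and compound 1 furthest. Going by the values given here, the one single-site step measured so far is a number 91 percentage points lower from compound 1 to compound 3 (beyond the scatter), a large loss.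

Compound 4 `COc1ccc2ncc(S(=O)(=O)c3cc(Cl)cc(Cl)c3)c(N3CCC(C)CC3)c2c1` is not yet measured. The change from compound 3 is 3,5-dichlorophenyl in place of 3-methoxyphenyl on a sulfonyl sulfur. It reverses the direction of the step from compound 1 to compound 3, putting a chlorinated aryl back on the sulfonyl sulfur; compound 2 shows that the same 3,5-dichlorophenyl, on a core differing at one other site, sits at a high value. A large upward step is therefore expected in this assay, a number 80 percentage points higher from compound 3 to compound 4 (beyond the scatter). Compound 4 is estimated at 80%, with a range from 55% to 95%.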

Compound 4, a percentage reported as inhibition, at one concentration (the size of the read-out at that concentration, not a potency): 87%
Estimate against measurement, compound 4: 7 percentage points below; the range from low to high includes it.
By their numbers in this assay, from the lowest: compound 3; then compound 2; then compounds 4 and 1 (each within the scatter of the next).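

In this assay the change on the sulfonyl sulfur gives a number 87 percentage points higher from compound 3 to compound 4 (beyond the scatter) on one and the same core, so among compounds 1, 3 and 4 the 3-methoxyphenyl of compound 3 is the one aryl that stands apart. The two chlorinated aryls cannot be told apart on this core, the swap to 3,5-dichlorophenyl giving a number 4 percentage points lower from compound 1 to compound 4 (within the scatter) and no separation between them. The other site now registers as well: with 3,5-dichlorophenyl held fixed, methoxy in place of methyl on an aromatic carbon gives a number 12 percentage points higher from compound 2 to compound 4 (beyond the scatter) as a modest step.

Still open, as far as these compounds go, is whether the loss in compound 3 follows the methoxy group itself, which a 3-chlorophenyl, or an aryl carrying an amine or a carboxylic acid, would test. No measurement shown here explains the size of that loss.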